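A few compounds are considered here, and "the series" means these few. Any claim that something is new, unique, unknown or untested is made for them only; others in the source may bear on it.

Measured so far in this series:
- compound 1 `CCN1CCN(c2cccc3c2CN([C@H](CCCNC(=O)c2cccs2)c2ccc(OC)c(OC)c2)C3=O)CC1`: 7 nM
- compound 2 `COc1ccc([C@@H](CCCN(C)S(=O)(=O)c2cccs2)N2Cc3c(cccc3N3CCN(C4CCC4)CC3)C2=O)cc1OC`: 4 nM
- compound 3 `COc1ccc([C@@H](CCCN(C)S(=O)(=O)c2cccs2)N2Cc3c(cccc3N3CCN(C)CC3)C2=O)cc1OC`: 16 nM

In a functional assay on CHO-K1 cells for antagonist activity at Urotensin-2 receptor (Rattus norvegicus), read by FLIPR and calcium flux, with a stated time of 1 h (on this read-out lower numbers stand for stronger inhibition and higher numbers for weaker inhibition), compound 1 stands second highest of the three numbers; compound 2 lies nearest, within the scatter, and compound 3 furthest, beyond it. Compound 4 `CCN1CCN(c2cccc3c2CN([C@H](CCCNS(=O)(=O)c2c[nH]cn2)c2ccc(OC)c(OC)c2)C3=O)CC1` is still to be measured. It differs from compound 1 in one place: (1H-imidazol-4-yl)sulfonyl in place of (thiophen-2-yl)carbonyl on an amine nitrogen. For the measured compounds named here, the only single-point step available, a 4.0-fold higher number from compound 2 to compound 3 (0.60 log units; beyond the scatter), concerns the amine nitrogen in a ring on the shared core and does not touch the chain nitrogen altered here. Going by the values given here, compounds 2 and 3 do carry a sulfonyl on that chain nitrogen where compound 1 carries a carbonyl, and the values of compounds 1 and 2 lie within the scatter of each other, but those two compounds also differ elsewhere, so no step can be computed for the carbonyl-to-sulfonyl exchange alone. Among the compounds with values here, the change to the ring and the added hydrogen-bond donor have no counterpart among the measured compounds. The step of a 1.7-fold higher number from compound 1 to compound 4 (0.23 log units; within the scatter) is therefore expected to be small, with wide uncertainty. Compound 4 is estimated at 12 nM, with a range of 4 nM to 40 nM.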

Compound 4, half-maximal inhibitory concentration: 23 nM
Beside the measured number, compound 4's estimate is 1.9-fold (0.28 log units) below it, within the range that was stated.
By their numbers in this assay, from the lowest: compounds 2 and 1 (each within the scatter of the next); then compounds 3 and 4 (each within the scatter of the next).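

For the compounds shown here, on the amine nitrogen of the chain, this assay registers the exchange of (thiophen-2-yl)carbonyl for (1H-imidazol-4-yl)sulfonyl as a 3.3-fold higher number from compound 1 to compound 4 (0.52 log units; beyond the scatter) and this is the first single-place step read at this nitrogen. The earlier step, a 4.0-fold higher number from compound 2 to compound 3 (0.60 log units; beyond the scatter) belongs to the amine nitrogen in a ring, so the new step shows that the chain nitrogen also responds to what it carries, though only modestly. The ring, the carbonyl-to-sulfonyl exchange and the added hydrogen-bond donor all change together here, and no supporting measurement bears on why the number rises.

The compounds shown leave open how the step divides between the linking group and the ring: (thiophen-2-yl)sulfonyl and (1H-imidazol-4-yl)carbonyl on this nitrogen, each on the core of compound 1, would separate the two. Also open, as far as these compounds go, is whether the ring hydrogen of the imidazole matters, which a 1-methylimidazolylsulfonyl group or a plain phenylsulfonyl group at the same place could test.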